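Replacing tert-Butyl with 4-Methylphenyl on the Amide Nitrogen

This account rests on a few compounds, and the source may have more. Where it says the series, first, only, none or still open, it means among the compounds named here.

Measured compounds:
compound 1, `C=CC1=C(C(=O)NCc2ccc(Cl)cc2)C(c2ccc(F)cc2)OC1`, 36900 nM
compound 2, `C=CC1=C(C(=O)NCc2ccccc2F)C(c2ccc(F)cc2)OC1`, 51400 nM
compound 3, `C=CC1=C(C(=O)NC(C)(C)C)C(c2ccc(F)cc2)OC1`, > 100000 nM

In a functional assay on QGY7701 cells (Homo sapiens) for cytotoxicity, read by MTT assay, with a stated time of 24 h (on this read-out higher numbers stand for weaker inhibition and lower numbers for stronger inhibition), compound 3 is reported only as a limit, > 100000 nM, so it stands at the weak end of the three numbers shown, and how far beyond that limit it lies is unknown. Compound 4 (`C=CC1=C(C(=O)Nc2ccc(C)cc2)C(c2ccc(F)cc2)OC1`) differs from it in a single place: 4-methylphenyl in place of tert-butyl on an amide-type nitrogen. The measured steps that touch this nitrogen run in the opposite direction, from an aromatic ring on a one-carbon chain to tert-butyl: an at least 2.7-fold higher number from compound 1 to compound 3 (0.43 log units; beyond the scatter) and an at least 1.9-fold higher number from compound 2 to compound 3 (0.28 log units; that floor lies within the scatter). Both steps move toward weaker inhibition, the first of them beyond the scatter, and both rest on the limit (the limit of > 100000 nM in this assay, at which 1 of the 3 values shown sits). Within the data shown here, putting an aromatic ring back on the nitrogen, now bound directly rather than through a chain, is therefore expected to recover some of that loss, although no measured pair shows an aryl directly on this nitrogen. The step from compound 3 to compound 4 is expected to be an at least 1.6-fold lower number from compound 3 to compound 4 (0.22 log units; that floor lies within the scatter), toward stronger inhibition. For compound 4 the estimate is 60000 nM, with a range from 25000 nM to 150000 nM.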

Compound 4, half-maximal inhibitory concentration: 59200 nM
Compound 4: the middle estimate sits 1.0-fold (0.01 log units) above what was measured; the range from low to high includes it.
By their numbers in this assay, from the lowest: compounds 1, 2 and 4 (each within the scatter of the next). At a limit, above all of these: compound 3.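

In this assay, 4-methylphenyl on the amide-type nitrogen gives a number level with those of the two benzyl amides: a 1.2-fold higher number from compound 2 to compound 4 (0.06 log units; within the scatter), and a 1.6-fold higher number from compound 1 to compound 4 (0.21 log units; within the scatter). Among the compounds shown, then, a one-carbon chain between the nitrogen and the aromatic ring is not required for a number in this range. The change from tert-butyl reads an at least 1.6-fold lower number from compound 3 to compound 4 (0.22 log units; that floor lies within the scatter), a floor and not a measured size, and it rests on a limit of the assay: the limit of > 100000 nM in this assay, at which 1 of the 4 values shown sits.

The compounds shown leave open what the methyl group of 4-methylphenyl contributes, and whether plain phenyl would read the same. They also leave open how a carboxylic acid or an amine on that ring, or a longer chain on the nitrogen, would change the number.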